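Aryl swap on a ring nitrogen: cytotoxicity notes

The source may hold more compounds than are shown below. What is called first, only, known or untested is meant among the compounds shown, and "the series" means these compounds.

Measured so far, in a functional assay on MV4-11 cells (Homo sapiens) for cytotoxicity, read by colorimetric assay and MTT assay, with a stated time of 3 days, tested at 1 uM; a higher number here means a weaker effect of the compound at the concentration tested, a lower number a stronger effect:
compound 1 `COc1ccc(-c2nc(-c3ccccc3)c(-c3ccc4c(c3)NC(=O)CO4)[nH]2)cc1`, 108%
compound 2 `Cc1ccccc1-n1cc(-c2ccccc2)c(-c2ccc3c(c2)NC(=O)CO3)n1`, 99.4%

Compound 2 holds the lower of the two numbers, but its gap to compound 1 lies within the usual scatter, so the two compounds read alike in this assay: neither shows a clear effect at the tested concentration. For the measured compounds named here, no step between measured compounds that differ in one place is available, so nothing is known about how a single change moves this read-out.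

Compound 3 `O=C1COc2ccc(-c3nn(-c4ccc(Cl)cc4)cc3-c3ccccc3)cc2N1` has not been measured. It differs from compound 2 in one place: 4-chlorophenyl in place of 2-methylphenyl on an aromatic nitrogen. Going by the values given here, with both measured compounds reading near full activity and no measured single-change step to draw on, the expected step of a number 0.6 percentage points higher from compound 2 to compound 3 (within the scatter) is none beyond the scatter. Compound 3 is therefore estimated at 100%, with a range from 84% to 112%.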

Compound 3, a percentage reported as activity, at one concentration (the size of the read-out at that concentration, not a potency): 108%
Compound 3: the middle estimate sits 8 percentage points below what was measured; the measured number falls inside the stated range.
By their numbers in this assay, from the lowest: compounds 2, 1 and 3 (each within the scatter of the next).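

In this assay, for the compounds shown here, the first single-change step reads a number 8.6 percentage points higher from compound 2 to compound 3 (within the scatter), so compound 2 and compound 3 read alike with 4-chlorophenyl in place of 2-methylphenyl on the aromatic nitrogen. For these two aryl groups, the choice at this position does not separate the compounds, and neither shows a clear effect at the tested concentration. No measured evidence accounts for this result.

Going by these compounds, it remains open whether any group on this nitrogen can give a read-out clearly lower than those of compound 2 and compound 3, for example a phenyl ring carrying a carboxylic acid or an amine. Going by these compounds alone, the phenyl group two ring bonds away also has no single-change step, so its contribution to the read-out remains unknown.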